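The compounds below may be only part of what the source reports. "The series", "measured", "known", "first", "only" and "open" are said of these compounds alone.

Values in an ADME assay on HepG2 cells (Homo sapiens) for cytotoxicity, with a stated time of 72 h; on this read-out lower numbers stand for an effect already at smaller amounts and higher numbers for an effect only at larger amounts of compound:
- compound 1 `CSc1ccc(NC(=O)Nc2cc(C)nc3ccccc23)cc1`: 16000 nM
- compound 2 `Cc1cc(NC(=O)Nc2ccc(N(C)C)cc2)c2ccccc2n1`: > 25000 nM, a limit of the assay and not a number
- compound 3 `Cc1cc(NC(=O)Nc2ccc(C(F)(F)F)cc2)c2ccccc2n1`: 23000 nM

Only compound 1 and compound 3 give actual numbers, and these two are not separated: a 1.4-fold higher number from compound 1 to compound 3 (0.16 log units; within the scatter). Compound 2 can be compared with them only through its limit.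

The open step leads to compound 4 `Cc1cc(NC(=O)Nc2ccc(C(=O)O)cc2)c2ccccc2n1`, with carboxy in place of trifluoromethyl on an aromatic carbon, para to a large group (carboxy in place of trifluoromethyl on an aromatic carbon).

Among the compounds with values here, the measured exchanges on an aromatic carbon are the only guide: an at least 1.5-fold higher number from compound 1 to compound 2 (0.19 log units; that floor lies within the scatter), a 1.4-fold higher number from compound 1 to compound 3 (0.16 log units; within the scatter) and an at least 1.0-fold lower number from compound 2 to compound 3 (0.03 log units; that floor lies within the scatter). None of them moves this assay beyond the scatter, although two of them rest on a limit. None involves carboxy, so the guide is indirect and the range has to stay wide. Within the data shown here, with a 1.4-fold higher number from compound 1 to compound 3 (0.16 log units; within the scatter) as the one step between actual numbers, no change beyond the scatter is expected for the new exchange. A reading of compound 4 at the limit of > 25000 nM in this assay, at which 1 of the 3 values shown sits, is also expected to be quite possible.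

The estimated step is a 1.1-fold higher number from compound 3 to compound 4 (0.04 log units; within the scatter).

For compound 4 the expected value is 25000 nM, with an estimated range of 13000 nM to 45000 nM.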

Compound 4, half-maximal effective concentration: > 25000 nM
Compound 4 gave a limit, no number (the forecaster's own chance of this, stated with the estimate: 60%); the middle value lies on the limit itself.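

In this assay, compound 4 gives a limit and not a number, so carboxy, with the hydrogen-bond donor that trifluoromethyl lacks, can stand on this aromatic carbon, para to a large group, without a measurable value appearing. The floors of the two readable steps are small, an at least 1.0-fold higher number from compound 3 to compound 4 (0.03 log units; that floor lies within the scatter) and an at least 1.5-fold higher number from compound 1 to compound 4 (0.19 log units; that floor lies within the scatter), while the step between compound 2 and compound 4 joins two limits and cannot be read. No exchange at this position has yet given a step shown to lie beyond the scatter, and compound 4 now stands with compound 2 at the end of the measurable range: the limit of > 25000 nM in this assay, at which 2 of the 4 values shown sit.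

From the compounds shown here alone, how far compound 2 and compound 4 lie past that limit stays open, so carboxy and dimethylamino cannot be ranked against each other, and carboxy can be compared with trifluoromethyl and methylsulfanyl only through floors. Also open, going by these compounds, is whether a primary amine, a methyl ester or a longer alkyl chain at this position would give a number separated from that of compound 1 by more than the scatter.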